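A few compounds are considered here, and "the series" means these few. Any claim that something is new, unique, unknown or untested is made for them only; others in the source may bear on it.

In a physicochemical assay for solubility (a higher number here means a more soluble compound, a lower number a less soluble compound), compound 1 `C[C@H](Oc1ccc(S(C)(=O)=O)cc1C(=O)N1Cc2ccccc2C1)C(F)(F)F` gives < 1 ug/mL as a limit of the assay, not a number. Compound 2 `C[C@H](Oc1ccc(S(C)(=O)=O)cc1C(=O)N1Cc2ccc(C(F)(F)F)cc2C1)C(F)(F)F` gives 1 ug/mL in this assay and compound 3 `CC(C)COc1ccc(S(C)(=O)=O)cc1C(=O)N1Cc2cc(C(F)(F)F)cnc2C1` gives 445 ug/mL as the highest number in the series, beyond the scatter from compound 2.

Compound 4 `CS(=O)(=O)c1ccc(-c2ccc(F)c(F)c2)c(C(=O)N2Cc3cc(C(F)(F)F)cnc3C2)c1` differs from compound 3 by 3,4-difluorophenyl in place of isobutoxy on an aromatic carbon with 3,4-difluorophenyl in place of isobutoxy.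

For the measured compounds named here, no measured step covers this exchange. Going by the values given here, the only step of a number no lower from compound 1 to compound 2 (the limit leaves the size open) concerns trifluoromethyl in place of hydrogen, and its size stays open. The series therefore gives only a weak guide: compound 3 at 445 ug/mL has much room to fall, and compound 2 at 1 ug/mL shows how low this series can sit. A fall beyond the scatter is expected, though its size is poorly fixed. The estimated step of an 11-fold lower number from compound 3 to compound 4 (1.05 log units; beyond the scatter) is accordingly a drop. Compound 4 is expected at 40 ug/mL with an estimated range from 4 ug/mL to 250 ug/mL in this assay for now.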

Compound 4, solubility: 42 ug/mL
The estimate for compound 4 lay 1.1-fold (0.02 log units) below the measured number, within the range that was stated.
By their numbers in this assay, from the lowest: compound 2; then compound 4; then compound 3.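

In this assay, the exchange of isobutoxy for 3,4-difluorophenyl, on an aromatic carbon para to a methylsulfonyl group, gives an 11-fold lower number from compound 3 to compound 4 (1.03 log units; beyond the scatter). For the compounds shown here, this is the first readable size for a change at this position, since the one earlier step concerns trifluoromethyl in place of hydrogen and its size stays open. This step can be read as a number because neither of its compounds sits at the limit of the assay: the limit of < 1 ug/mL in this assay, at which 1 of the 4 values shown sits.

With a single exchange, the step cannot be divided between the loss of isobutoxy, the entry of an aromatic ring and the two fluorines on that ring. Going by these compounds, how a phenyl without fluorine, or a chain ending in an amine, would stand at this position remains open.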